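A few compounds are considered here, and "the series" means these few. Any claim that something is new, unique, unknown or untested is made for them only; others in the source may bear on it.

The series is built on one shared core, to which different groups are attached, and the compounds are compared in an assay on HEK293 cells for displacement of a labelled ligand from NPC1-like intracellular cholesterol transporter 1 (Homo sapiens); a lower number here means a stronger inhibitor, a higher number a weaker inhibitor. Compound 1 `CC(C)(C)c1ccc(C(=O)N2CCC3(CC2)C(=O)N(CC(=O)NCCO)CN3c2ccccc2)cc1` gives 1000 nM. Among the compounds with values here, compound 2 `O=C(CN1CN(c2ccccc2)C2(CCN(C(=O)c3ccc(C4CCCCC4)cc3)CC2)C1=O)NCCO` gives 2000 nM and so stands second highest of the three numbers known, with the step of a 2.0-fold higher number from compound 1 to compound 2 (0.30 log units; within the scatter) being the only difference between it and compound 1. Compound 3 `CC(C)(C)c1ccc(C(=O)N2CCC3(CC2)C(=O)N(CC(=O)N2CCN(S(C)(=O)=O)CC2)CN3c2ccccc2)cc1` gives 19000 nM, the highest number of the three, reached through the step of a 19-fold higher number from compound 1 to compound 3 (1.28 log units; beyond the scatter).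

Compound 4 `CC1CCCN(C(=O)CN2CN(c3ccccc3)C3(CCN(C(=O)c4ccc(C5CCCCC5)cc4)CC3)C2=O)C1` has not yet been measured. It differs from compound 2 in one place: 3-methylpiperidin-1-yl in place of (2-hydroxyethyl)amino on a carbonyl carbon. Within the data shown here, the measured step that bears on this is the one from compound 1 to compound 3, where the same (2-hydroxyethyl)amino group was exchanged for a six-membered ring on the same carbonyl carbon and the number rose by a 19-fold higher number from compound 1 to compound 3 (1.28 log units; beyond the scatter). The change here also removes both hydrogen-bond donors and the acceptor of the leaving group, so a rise of similar kind is expected, estimated as a 7.5-fold higher number from compound 2 to compound 4 (0.88 log units; beyond the scatter). Compound 4 is therefore expected to give about 15000 nM, within a range of 4000 nM to 60000 nM.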

Compound 4, half-maximal inhibitory concentration: 3600 nM
Beside the measured number, compound 4's estimate is 4.2-fold (0.62 log units) above it, outside the stated range (below it).
By their numbers in this assay, from the lowest: compounds 1, 2 and 4 (each within the scatter of the next, the first and the last beyond it); then compound 3.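

In this assay, the exchange of (2-hydroxyethyl)amino for 3-methylpiperidin-1-yl on this carbonyl carbon gives a 1.8-fold higher number from compound 2 to compound 4 (0.26 log units; within the scatter), so the two compounds cannot be told apart even though the entering group carries no hydrogen-bond donors or acceptors. In this pair, then, the donors and acceptor of the leaving group are not needed to keep the number, and a six-membered ring on this carbon does not by itself bring a large step such as a 19-fold higher number from compound 1 to compound 3 (1.28 log units; beyond the scatter), seen with 4-(methylsulfonyl)piperazin-1-yl. Nothing available here explains why these two ring exchanges differ.

Open, as far as these compounds go, is whether 4-(methylsulfonyl)piperazin-1-yl would give the same large step on the cyclohexyl compounds as on the tert-butyl ones. From the compounds shown here alone, it is also open how an unsubstituted piperidin-1-yl, a morpholin-4-yl or a longer chain ending in a carboxylic acid would behave on this carbonyl carbon.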